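This account rests on a few compounds, and the source may have more. Where it says the series, first, only, none or still open, it means among the compounds named here.

Measured so far:
compound 1 `CC(C)S(=O)(=O)Nc1ccc(N(C)C(=O)c2ccccc2)cc1`: 0.1 mg/kg
compound 2 `CC(C)S(=O)(=O)Nc1ccc(NC(=O)c2ccccc2)cc1`: 1 mg/kg
compound 3 `CC(C)S(=O)(=O)Nc1ccc(NS(=O)(=O)c2ccc(F)cc2)cc1`: 10 mg/kg

All three numbers come from a functional assay on the whole organism with Mus musculus as the target, with a stated time of 20 min; a higher number here means that more compound is needed for the effect, a lower number that less compound is needed. Compound 1 has the lowest number of the three; compound 2 stands nearest to it and compound 3 furthest. For the measured compounds named here, the single measured step is a 10-fold higher number from compound 1 to compound 2 (1.00 log units; beyond the scatter). Compound 4 `CC(C)S(=O)(=O)N(C)c1ccc(N(C)C(=O)c2ccccc2)cc1` is not yet measured. It differs from compound 1 by methyl in place of hydrogen on a sulfonamide nitrogen. The measured step concerns a different nitrogen, so it guides the present change only loosely, though it shows that adding or removing a methyl on a nitrogen of this core can shift the number well beyond the scatter. The expectation for compound 4 is a small step toward a higher number, a 3.0-fold higher number from compound 1 to compound 4 (0.48 log units; beyond the scatter). Compound 4 is therefore estimated at 0.3 mg/kg, within a range of 0.05 mg/kg to 3 mg/kg.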

Compound 4, minimum effective dose: 1 mg/kg
Estimate against measurement, compound 4: 3.3-fold (0.52 log units) below; measured number inside the range.
By their numbers in this assay, from the lowest: compound 1; then compounds 2 and 4 (each within the scatter of the next); then compound 3.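

In this assay, methyl in place of hydrogen on the sulfonamide nitrogen gives a 10-fold higher number from compound 1 to compound 4 (1.00 log units; beyond the scatter), so this nitrogen also affects the dose needed, and here the hydrogen form needs less compound. On the amide-type nitrogen the direction is reversed: the methyl form, compound 1, has the lower number, and replacing that methyl with hydrogen gives a 10-fold higher number from compound 1 to compound 2 (1.00 log units; beyond the scatter), so the same methyl has opposite outcomes at the two nitrogens. Nothing available explains this shift.

Still open, from the compounds shown here alone, is whether an ethyl group or a longer chain on the sulfonamide nitrogen would follow methyl. An acetyl group there is equally unexplored.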